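The source may hold more compounds than are shown below. What is called first, only, known or untested is meant among the compounds shown, and "the series" means these compounds.

Compound 1 `O=C(CN1CCN(c2nnc(Cc3ccncc3)c3ccccc23)CC1)Nc1ccc(F)c(Cl)c1` is the standout of the three compounds measured in a functional assay on MDA-MB-231 cells (Homo sapiens) for cytotoxicity, read by MTT assay, with a stated time of 72 h; a lower number here means a stronger inhibitor, a higher number a weaker inhibitor: compound 1 gives 4 nM, the lowest number of the set. Compound 2 `O=C(CN1CCN(c2nnc(Cc3ccccc3)c3ccccc23)CC1)Nc1ccc(F)c(Cl)c1`, in this assay, gives 7360 nM, and compound 3 `Cc1ccccc1NC(=O)CN1CCN(c2nnc(Cc3ccccc3)c3ccccc23)CC1` gives 17300 nM. The step of a 1800-fold higher number from compound 1 to compound 2 (3.26 log units; beyond the scatter) is the dominant one in the series, while the step of a 2.4-fold higher number from compound 2 to compound 3 (0.37 log units; beyond the scatter) is far smaller.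

Compound 4 `O=C(CN1CCN(c2nnc(Cc3ccncc3)c3ccccc23)CC1)Nc1cc(C(F)(F)F)ccc1Cl` is the next compound to be measured in this assay. It keeps the pyridin-4-yl group of compound 1 intact and alters only the aryl group on the amide nitrogen: 2-chloro-5-(trifluoromethyl)phenyl in place of 3-chloro-4-fluorophenyl on an amide-type nitrogen.

Going by the values given here, of the two measured steps, only the one from compound 2 to compound 3 bears on this change, since it too exchanges the aryl group on the amide-type nitrogen, and there the effect was modest. The swap at the saturated chain carbon bound to an aromatic carbon, which carried the large step, is untouched here. Compound 4 is therefore expected to stay close to compound 1, with a step of about a 2.5-fold higher number from compound 1 to compound 4 (0.40 log units; beyond the scatter), most likely a slight weakening. The estimate for compound 4 in this assay is 10 nM, with a range from 2 nM to 60 nM.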

Compound 4, half-maximal inhibitory concentration: 3.7 nM
Compound 4: middle estimate off by 2.7-fold (0.43 log units), on the high side; the range from low to high includes it.
By their numbers in this assay, from the lowest: compounds 4 and 1 (each within the scatter of the next); then compound 2; then compound 3.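

In this assay, placing 2-chloro-5-(trifluoromethyl)phenyl in place of 3-chloro-4-fluorophenyl on the amide-type nitrogen gives a 1.1-fold lower number from compound 1 to compound 4 (0.03 log units; within the scatter), so with pyridin-4-yl retained, this position accepts an aryl group of 11 heavy atoms in place of one of 8 without a change beyond the scatter. Going by these compounds alone, the only earlier exchange at this nitrogen, a 2.4-fold higher number from compound 2 to compound 3 (0.37 log units; beyond the scatter), involved a different incoming group on compounds carrying phenyl rather than pyridin-4-yl, so compound 4 gives the first reading of this position with pyridin-4-yl in place. No measurement at hand explains why the two aryl groups give values within the scatter of each other.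

The aryl groups shown on the amide-type nitrogen carry only halogen, trifluoromethyl or methyl substituents, so it remains open whether an unsubstituted phenyl, a pyridin-3-yl or a phenyl bearing a carboxylic acid would be accepted there. Also open is how narrow the requirement behind a 1800-fold higher number from compound 1 to compound 2 (3.26 log units; beyond the scatter) is, since the compounds shown do not tell whether a pyridin-3-yl or a pyridin-2-yl on the chain carbon would behave like pyridin-4-yl or like phenyl.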